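Methoxy to hydroxy: a solubility question at the assay limit

A few compounds are considered here, and "the series" means these few. Any claim that something is new, unique, unknown or untested is made for them only; others in the source may bear on it.

Of the compounds shown here, two have so far been read in a physicochemical assay for solubility; on this read-out higher numbers stand for higher solubility and lower numbers for lower solubility: compound 1 (`CNC(=O)c1cc(C(=O)N[C@H]2CC[C@H](OC)CC2)n([C@@H](C)c2ccccc2)n1`) and compound 2 (`CNC(=O)c1cc(C(=O)N[C@H]2CC[C@H](OC)CC2)c([C@@H](C)c2ccccc2)o1`). Compound 1 gives >= 161 ug/mL, which is a limit of the assay and not a number. Compound 2 gives >= 192 ug/mL, which is likewise a limit. Among the measured compounds shown here, compound 2 therefore has no exact value, and neither does the only other compound measured, so the two cannot be ranked.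

The next compound, compound 3 (`CNC(=O)c1cc(C(=O)N[C@H]2CC[C@H](O)CC2)c([C@@H](C)c2ccccc2)o1`), keeps the core of compound 2 and differs from it in one place: hydrogen in place of methyl on an oxygen on a saturated carbon. This is hydrogen in place of methyl on an oxygen on a saturated carbon, turning 4-methoxycyclohexyl into 4-hydroxycyclohexyl. For the measured compounds named here, no measured pair shows this change, so the expectation has no direct precedent. Compound 2 already sits at its limit of >= 192 ug/mL in this assay, so no change beyond the scatter is expected. The expected step of a number no higher from compound 2 to compound 3 (the limit leaves the size open) is estimated to lie within the scatter. For compound 3 the estimated solubility is 190 ug/mL, with an expected range of 110 ug/mL to 300 ug/mL.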

Compound 3, solubility: >= 184 ug/mL
Compound 3 ended at the assay's limit; the forecaster's own chance of this, stated with the estimate: 65%; the middle value lies beyond the limit too.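

In this assay, compound 2 and compound 3 both stand at limits of the assay and not at numbers, and no step can be read between them. The compounds shown leave open whether going from 4-methoxycyclohexyl to 4-hydroxycyclohexyl makes any difference in this assay, and how compound 2 and compound 3 would rank on exact values.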